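Working notes: ester variation in a calcium channel antagonist series

A few compounds are considered here, and "the series" means these few. Any claim that something is new, unique, unknown or untested is made for them only; others in the source may bear on it.

compound 1 `COC(=O)C1=C(C)NC(C)=C(C(=O)OCCCl)C1c1cccc([N+](=O)[O-])c1` — a functional assay on HEK293 cells for antagonist activity at Voltage-dependent L-type calcium channel subunit alpha-1C (Oryctolagus cuniculus), read by FLIPR; on this read-out lower numbers stand for stronger inhibition and higher numbers for weaker inhibition: 26 nM
compound 2 `COC(=O)C1=C(C)NC(C)=C(C(=O)OC2C=CCCC2)C1c1cccc([N+](=O)[O-])c1` — this assay: 10 nM
compound 3 `COC(=O)C1=C(C)NC(C)=C(C(=O)OCc2ccc(F)c(F)c2)C1c1cccc([N+](=O)[O-])c1` — this assay: 7 nM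

Compound 3 carries the lowest number of the three in this assay; its gap to compound 2 is within the scatter, whereas a 3.7-fold lower number from compound 1 to compound 3 (0.57 log units; beyond the scatter) lies beyond it. Compound 4 `COC(=O)C1=C(C)NC(C)=C(C(=O)OCc2ccc(OC)c(OC)c2)C1c1cccc([N+](=O)[O-])c1` differs from compound 3 in one place: 3,4-dimethoxyphenyl in place of 3,4-difluorophenyl on a saturated chain carbon bound to an oxygen next to a carbonyl group. Going by the values given here, the steps that bear on this are the ester changes already seen, a 3.7-fold lower number from compound 1 to compound 3 (0.57 log units; beyond the scatter) and a 1.4-fold lower number from compound 2 to compound 3 (0.15 log units; within the scatter), both modest, with a 2.6-fold lower number from compound 1 to compound 2 (0.41 log units; beyond the scatter) of similar size. Among the compounds with values here, none of the measured steps compares two substituted benzyl esters with each other, so the effect of swapping the substituents is untested. The change from compound 3 to compound 4 is therefore expected to give no step beyond the scatter in this assay, a 1.7-fold higher number from compound 3 to compound 4 (0.23 log units; within the scatter). Compound 4 is estimated at 12 nM, with a range from 4 nM to 40 nM.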

Compound 4, half-maximal inhibitory concentration: 112 nM
Compound 4: middle estimate off by 9.3-fold (0.97 log units), on the low side, outside the stated range (above it).
By their numbers in this assay, from the lowest: compounds 3 and 2 (each within the scatter of the next); then compound 1; then compound 4.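

In this assay, the ester position proves sensitive to the substituents on the benzyl ring: 3,4-dimethoxybenzyl in place of 3,4-difluorobenzyl gives a large loss (a 16-fold higher number from compound 3 to compound 4 (1.20 log units; beyond the scatter)). A benzyl ester alone therefore does not secure a low number, and compound 4 also falls behind both non-benzyl esters (an 11-fold higher number from compound 2 to compound 4 (1.05 log units; beyond the scatter); a 4.3-fold higher number from compound 1 to compound 4 (0.63 log units; beyond the scatter)). No available evidence accounts for this change.

Open, as far as these compounds go, is where an unsubstituted benzyl ester, or a benzyl ester carrying methyl groups, would fall relative to compound 3 and compound 4. Also open, from the compounds shown here alone, is whether a single methoxy group would suffice for the loss.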